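The source may report more compounds than this note shows. Statements on the series, on what has been measured and on what is new or still open speak of the compounds shown alone.

Measured so far:
compound 1 `CC1(C)OB(c2ccc(COc3ccc(CNC(=O)[C@@H]4CCC(=O)N4Cc4ccccc4)cc3)cc2)OC1(C)C` gives 50 nM in an assay on HEK293 cells for inhibition of Ataxin-2 (Mus musculus), read by fluorescence and Amplex Red; a lower number here means a stronger inhibitor, a higher number a weaker inhibitor.
compound 2 `CC1(C)OB(c2ccc(COc3ccc(CNC(=O)[C@@H]4CCC(=O)N4Cc4ccc(F)cc4)cc3)cc2)OC1(C)C` gives 120 nM in this assay.
compound 3 `O=C(O)c1ccc(COc2ccc(CNC(=O)[C@@H]3CCCN3Cc3ccccc3)cc2)cc1` gives only a limit of the assay in this assay: > 5000 nM.

Compound 1 and compound 2 share one core and differ by a single change, (fluoro in place of hydrogen on an aromatic carbon). That change costs a 2.4-fold higher number from compound 1 to compound 2 (0.38 log units; beyond the scatter). Compound 3 carries a different core; how the two cores differ is not broken down here. Compound 3 sits at the limit, (the limit of > 5000 nM in this assay, at which 1 of the 3 values shown sits), so no number for it is known, only that it lies at or beyond the limit.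

Compound 4 `O=C(O)c1ccc(COc2ccc(CNC(=O)[C@@H]3CCCN3Cc3ccc(F)cc3)cc2)cc1` is the analogue of compound 3 carrying the same change, (fluoro in place of hydrogen on an aromatic carbon). Both occurrences of this change sit on the same kind of position, so it is read as the same change. On the measured pair it gave a modest loss; nothing in the measured compounds suggests a gain. Starting from a limit, a modest loss or no change would keep compound 4 at the limit. The expected step is a step that the limit leaves unreadable from compound 3 to compound 4. Compound 4 is estimated at 9000 nM, in a range from 5000 nM to 25000 nM, and is expected to report again only a limit.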

Compound 4, half-maximal inhibitory concentration: 800 nM
Compound 4: the middle estimate sits 11-fold (1.05 log units) above what was measured, and the stated range ends above it.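

Fluoro in place of hydrogen does not carry over unchanged between the two cores in this assay: the same change on two cores in this assay, a 2.4-fold higher number (0.38 log units; beyond the scatter) from compound 1 to compound 2 and an at least 6.2-fold lower number (0.79 log units; beyond the scatter) from compound 3 to compound 4, at least 15-fold (1.17 log units) apart, beyond the scatter of two such steps

From the compounds shown here alone, on the core of compound 3 the change goes the opposite way to the measured pair, with an at least 6.2-fold lower number from compound 3 to compound 4 (0.79 log units; beyond the scatter), and its full size stays unknown, the starting value being only a limit of the assay. This shows that, for these two pairs, the size and direction of the step depend on the core, but it does not identify which part of the core matters, and two pairs set no rule for any further core.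

The compounds shown leave open which difference between the cores sets the direction of the step; the carboxylic acid and the boronate ester each appear on one core only. Also open, going by these compounds, is whether chloro in place of fluoro on the benzyl group would follow the same split between the two cores.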